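A few compounds are considered here, and "the series" means these few. Any claim that something is new, unique, unknown or untested is made for them only; others in the source may bear on it.

In an assay on cells (Hepatocyte) for inhibition of glucokinase regulatory protein (Mus musculus), with stated times of 20 min and 40 min (on this read-out lower numbers stand for an effect already at smaller amounts and higher numbers for an effect only at larger amounts of compound), compound 1 `CC#C[C@H]1CN(S(=O)(=O)c2ccc(N)nc2)CCN1c1ccc([C@@](O)(CO)C(F)(F)F)cc1` gives 89 nM, the lowest number among the measured compounds. Compound 3 `CC#C[C@H]1CN(S(=O)(=O)c2ccc(N)nc2)CCN1c1ccc(C(=O)NC)cc1` gives 4050 nM, a step of a 46-fold higher number from compound 1 to compound 3 (1.66 log units; beyond the scatter). Compound 2 `CC#C[C@H]1CN(S(=O)(=O)c2ccc(N)nc2)CCN1c1ccc(S(=O)(=O)Nc2ccccc2)cc1` reaches only the assay limit of > 12500 nM. Compound 4 `CC#C[C@H]1CN(S(=O)(=O)c2ccc(N)nc2)CCN1c1ccc([C@](O)(CO)C(F)(F)F)cc1` keeps every atom and bond of compound 1: the two compounds have the same atoms and bonds and differ only in configuration as drawn: 1 of 2 stereo elements differ; a stereocentre at a saturated chain carbon is drawn R in compound 1 and S in compound 4. For the measured compounds named here, no measured step changes configuration alone; the steps to compound 2 (an at least 140-fold higher number from compound 1 to compound 2 (2.14 log units; beyond the scatter)) and to compound 3 replace the whole group, so they do not directly guide this change. Going by the values given here, since the group carrying the inverted centre is the one that sets compound 1 apart, the number for compound 4 is expected to rise, an estimated step of a 6.7-fold higher number from compound 1 to compound 4 (0.83 log units; beyond the scatter). The estimate for compound 4 is 600 nM, with a range from 100 nM to 5000 nM.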

Compound 4, half-maximal effective concentration: 98 nM
Beside the measured number, compound 4's estimate is 6.1-fold (0.79 log units) above it, and the stated range ends above it.
By their numbers in this assay, from the lowest: compounds 1 and 4 (each within the scatter of the next); then compound 3. At a limit, above all of these: compound 2.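

In this assay, inverting the stereocentre in the 1,2-dihydroxy-1-(trifluoromethyl)ethyl group leaves the number within the scatter: a 1.1-fold higher number from compound 1 to compound 4 (0.04 log units; within the scatter). The advantage of this group therefore holds in both drawn configurations, with a 41-fold lower number from compound 3 to compound 4 (1.62 log units; beyond the scatter) against methylcarbamoyl and an at least 120-fold lower number from compound 2 to compound 4 (2.10 log units; beyond the scatter) against phenylsulfamoyl. The second of these steps starts from a limit of the assay for compound 2, not from a number. From the compounds shown here alone, it remains open whether a simpler hydroxymethyl group or a carboxylic acid in the same place would keep the number as low, and whether inverting the other stereocentre would matter more.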